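This account rests on a few compounds, and the source may have more. Where it says the series, first, only, none or still open, it means among the compounds named here.

Measured so far in an ADME assay on L02 cells (Homo sapiens) for cytotoxicity, read by MTT assay, with a stated time of 24 h; a higher number here means a weaker inhibitor, a lower number a stronger inhibitor:
- Compound 1 `O=C1/C(=C/c2ccccc2F)CN(S(=O)(=O)c2ccc(F)cc2)C/C1=C\c1ccccc1F`: 19100 nM
- Compound 2 `CC(=O)Nc1ccc(S(=O)(=O)N2C/C(=C\c3ccccc3F)C(=O)/C(=C/c3ccccc3F)C2)cc1`: 11600 nM
- Compound 3 `COc1cc(/C=C2\CN(S(=O)(=O)c3ccc(F)cc3)C/C(=C\c3cccc([N+](=O)[O-])c3)C2=O)cc(OC)c1OC`: 18800 nM

Compound 2, at 11600 nM, stands level with the other two, since its number lies within the usual scatter of both compound 1 and compound 3. Compound 4 `COc1cc(/C=C2\CN(S(=O)(=O)c3ccc(NC(C)=O)cc3)C/C(=C\c3ccccc3F)C2=O)cc(OC)c1` keeps the acetamido group of compound 2 but carries 3,5-dimethoxyphenyl in place of 2-fluorophenyl on a double-bonded chain carbon bound to a double-bonded ring carbon.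

Within the data shown here, no measured step tests this exact swap. Among the measured compounds shown here, the only one available changes another part of the molecule, and it is small: a 1.6-fold lower number from compound 1 to compound 2 (0.22 log units; within the scatter). Compound 3 also bears methoxy groups on one of its phenyl rings, and it gives 18800 nM, which is within the scatter of compound 2. Nothing here points to a clear shift in either direction, so the expected step is no larger than the scatter: a 1.1-fold higher number from compound 2 to compound 4 (0.05 log units; within the scatter). The estimate for compound 4 is 13000 nM, with an expected range of 6500 nM to 30000 nM.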

Compound 4, half-maximal inhibitory concentration: 15400 nM
The estimate for compound 4 lay 1.2-fold (0.07 log units) below the measured number; measured number inside the range.
By their numbers in this assay, from the lowest: compounds 2, 4, 3 and 1 (each within the scatter of the next).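

In this assay, putting 3,5-dimethoxyphenyl in place of 2-fluorophenyl on a double-bonded chain carbon bound to a double-bonded ring carbon gives a 1.3-fold higher number from compound 2 to compound 4 (0.12 log units; within the scatter). This is the first direct test of this position among the compounds shown, and it shows that a group with more heavy atoms and two hydrogen-bond acceptors can replace the fluorinated one without a change that can be told from the scatter. No supporting measurement bears on this result, so it stays an observation without an explanation.

The compounds shown leave open whether this position would stay as undemanding with a different kind of group, such as an amine or a carboxylic acid in place of the phenyl ring. They also leave open whether the same swap would behave alike with another group on the sulfonyl-bound ring.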